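Swapping methyl for tert-butyl on compound 3

The source may report more compounds than this note shows. Statements on the series, on what has been measured and on what is new or still open speak of the compounds shown alone.

compound 1 `Cc1ccc(CNc2nc(Nc3ccc(N4CCN(C)CC4)cn3)ncc2Cl)cc1`: 18600 nM
compound 2 `COc1ccc(CNc2nc(Nc3ccc(N4CCN(C)CC4)cn3)ncc2Cl)cc1`: 14900 nM
compound 3 `Cc1ccc(Nc2nc(Nc3ccc(N4CCN(C)CC4)cn3)ncc2Cl)cc1`: 4030 nM

In a functional assay on MDA-MB-231 cells (Homo sapiens) for inhibition, read by CCK-8 assay, with a stated time of 48 h (a higher number here means a weaker inhibitor of growth, a lower number a stronger inhibitor of growth), compound 3, at 4030 nM, has the lowest number of the three. Compound 4 `CN1CCN(c2ccc(Nc3ncc(Cl)c(Nc4ccc(C(C)(C)C)cc4)n3)nc2)CC1` differs from it in one group: tert-butyl in place of methyl on an aromatic carbon. The closest measured change, methoxy in place of methyl on an aromatic carbon, gave a 1.2-fold lower number from compound 1 to compound 2 (0.10 log units; within the scatter). The larger steps, a 4.6-fold lower number from compound 1 to compound 3 (0.66 log units; beyond the scatter) and a 3.7-fold lower number from compound 2 to compound 3 (0.57 log units; beyond the scatter), replaced a benzyl group with a phenyl group, so they bear on this change only loosely. Among the measured compounds shown here, no measured compound carries tert-butyl, so the direction stays open, and no step beyond the scatter is expected. The expected change is a 1.2-fold lower number from compound 3 to compound 4 (0.06 log units; within the scatter). Compound 4 is estimated at 3500 nM. Its expected range runs from 1300 nM to 9000 nM.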

Compound 4, concentration for 50% growth inhibition: 16200 nM
For compound 4 the middle estimate is 4.6-fold (0.67 log units) below the measured one; the whole stated range lies below it.
By their numbers in this assay, from the lowest: compound 3; then compounds 2, 4 and 1 (each within the scatter of the next).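

The position para to a large group on the phenyl ring responds to the group it carries: in this assay, tert-butyl in place of methyl gives a step beyond the scatter (a 4.0-fold higher number from compound 3 to compound 4 (0.60 log units; beyond the scatter)), unlike methoxy in place of methyl (a 1.2-fold lower number from compound 1 to compound 2 (0.10 log units; within the scatter)). With tert-butyl, the phenyl compound no longer stands apart from the benzyl compounds (a 1.1-fold higher number from compound 2 to compound 4 (0.04 log units; within the scatter); a 1.1-fold lower number from compound 1 to compound 4 (0.06 log units; within the scatter)). Nothing available explains this step. With only methyl and tert-butyl shown on the phenyl compounds, how ethyl, isopropyl, an amine or a carboxylic acid would read at this position stays open.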